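This account rests on a few compounds, and the source may have more. Where it says the series, first, only, none or still open, it means among the compounds named here.

Measured so far:
- compound 1, `NNC(=O)c1cc(-c2ccccc2)nc2ccccc12`: > 300000 nM
- compound 2, `CC(C)Oc1cc(C(=O)NCCCN(C)C)c2ccccc2n1`: 122000 nM

In an ADME assay on RD cells (Homo sapiens) for cytotoxicity, read by neutral red uptake, with a stated time of 3 days (on this read-out higher numbers stand for lower toxicity in this test and lower numbers for higher toxicity in this test), compound 1 reaches only a limit of the assay, > 300000 nM, and no number sits behind it; this is the case described by the limit of > 300000 nM in this assay, at which 1 of the 2 values shown sits. Compound 2 gives 122000 nM in this assay, a plain number. Compound 3, `CCN(CC)CCCNC(=O)c1cc(-c2ccccc2)nc2ccccc12`, is still to be measured in this assay. It differs from compound 1 by 3-(diethylamino)propyl in place of amino on an amide-type nitrogen. Going by the values given here, no step between two measured compounds carries this same change, so its size cannot be read off directly. What the data do show is that compound 2, which also carries an aminoalkyl chain on its amide nitrogen, returns a number where compound 1 returns only a limit.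

Compound 3 is therefore expected to come out at 100000 nM in this assay, within roughly 30000 nM to 300000 nM. The step of an at least 3.0-fold lower number from compound 1 to compound 3 (0.47 log units; beyond the scatter) is expected to run toward higher toxicity and beyond the usual scatter, with a real chance that compound 3 again reports only a limit.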

Compound 3, half-maximal cytotoxic concentration: 45400 nM
Estimate against measurement, compound 3: 2.2-fold (0.34 log units) above; measured number inside the range.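

In this assay, 3-(diethylamino)propyl in place of amino on the amide-type nitrogen gives an at least 6.6-fold lower number from compound 1 to compound 3 (0.82 log units; beyond the scatter), a change toward higher toxicity in this test, so a change at this position can register on this read-out. Compound 1 stands at > 300000 nM, which is a limit of the assay and not a number. The step from it therefore has a known minimum size but no known full size, and compound 3, at 45400 nM, gives this series its first plain number on the core of compound 1: the limit of > 300000 nM in this assay, at which 1 of the 3 values shown sits.

Going by these compounds alone, the single step exchanges the whole group at once, so it remains open whether the terminal diethylamino nitrogen or the carbon chain accounts for the change; a plain propyl group, a 3-(dimethylamino)propyl group or a longer aminoalkyl chain on the same nitrogen would help separate the two. As far as these compounds go, this change is also seen on the core of compound 1 alone, so whether a step of similar size holds on another core remains unknown.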